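Aryl carbamate series: phenyl replaces pyridin-3-yl

The source may hold more compounds than are shown below. What is called first, only, known or untested is meant among the compounds shown, and "the series" means these compounds.

Measured so far:
- compound 1, `CC(C)(C)c1ccc(COC(=O)N[C@H]2CNC2=O)cc1`: 310 nM
- compound 2, `O=C(N[C@H]1CNC1=O)OCc1ccc(-c2cccnc2)cc1`: 8110 nM

In an assay on HEK293 cells for inhibition of N-acylethanolamine-hydrolyzing acid amidase (Homo sapiens), read by fluorescence, with stated times of 10 min and 50 min (on this read-out higher numbers stand for weaker inhibition and lower numbers for stronger inhibition), compound 1 gives 310 nM and compound 2 gives 8110 nM. Within the data shown here, compound 2 therefore carries the highest of the two numbers, with compound 1 as its only neighbour; the step of a 26-fold higher number from compound 1 to compound 2 (1.42 log units; beyond the scatter) is the one measured change at this position and it is large.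

Compound 3, `O=C(N[C@H]1CNC1=O)OCc1ccc(-c2ccccc2)cc1`, is not yet measured. It differs from compound 2 by phenyl in place of pyridin-3-yl on an aromatic carbon. Among the measured compounds shown here, the only step that bears on the site is a 26-fold higher number from compound 1 to compound 2 (1.42 log units; beyond the scatter), which lost a great deal when the tert-butyl gave way to pyridin-3-yl. Nothing measured separates the contribution of the ring itself from that of its nitrogen, so the direction for compound 3 rests on one data point. A phenyl is expected to sit between the two measured ends: the step of a 4.1-fold lower number from compound 2 to compound 3 (0.61 log units; beyond the scatter) is the expected partial recovery toward compound 1. For compound 3 the estimated value in this assay is 2000 nM, with a range from 500 nM to 8000 nM.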

Compound 3, half-maximal inhibitory concentration: 513 nM
Compound 3: the middle estimate sits 3.9-fold (0.59 log units) above what was measured; low and high end bracket the measured number.
By their numbers in this assay, from the lowest: compounds 1 and 3 (each within the scatter of the next); then compound 2.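

In this assay, the exchange of pyridin-3-yl for phenyl gives a 16-fold lower number from compound 2 to compound 3 (1.20 log units; beyond the scatter). The two groups match in heavy-atom count and differ by one ring nitrogen in place of a ring carbon, so the large loss seen with pyridin-3-yl does not extend to every six-membered aromatic ring at this position, and in this pair the change of that single ring atom carries the whole step. The second new comparison, a 1.7-fold higher number from compound 1 to compound 3 (0.22 log units; within the scatter), lies within the scatter, so phenyl and tert-butyl cannot be told apart here, and this position accepts either a branched alkyl group or an all-carbon aromatic ring; nothing at hand accounts for the effect of the ring nitrogen.

The compounds shown leave open whether the penalty follows the nitrogen wherever it stands in the ring, as a pyridine attached through a different ring carbon or a pyrimidine would test. Also open, from the compounds shown here alone, is how far the phenyl ring accepts further groups, such as a methoxy group or an amine, and whether a saturated cyclohexyl ring behaves like phenyl or tert-butyl.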